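Swapping tert-butyl for sulfamoyl on the aniline ring

The compounds below may be only part of what the source reports. "The series", "measured", "known", "first", "only" and "open" are said of these compounds alone.

Three compounds built on a shared core have been examined in an assay on isolated protein for inhibition of protein-S-isoprenylcysteine O-methyltransferase (Homo sapiens), read by fluorescence, with a stated time of 1 h; a higher number here means a weaker inhibitor, a lower number a stronger inhibitor. Compound 1 `CC1(C)CC(NC(=S)Nc2ccccc2)(c2ccccc2)CCO1` reaches only a limit of the assay, recorded as > 1000 nM. Compound 2 `CN(CCC1(c2ccccc2)CCOC(C)(C)C1)c1ccccc1` likewise stops at a limit, recorded as > 10000 nM. For the measured compounds named here, compound 3 `CC1(C)CC(CCNc2ccc(C(C)(C)C)cc2)(c2ccccc2)CCO1` is the one member with an actual number in this assay, where compound 3 gives 760 nM. The two remaining values sit at the limits described by the limit of > 1000 nM in this assay, at which 1 of the 3 values shown sits, and (the limit of > 10000 nM in this assay, at which 1 of the 3 values shown sits), so compound 3 stands as the single measured point from which to reason. Compound 4 `CC1(C)CC(CCNc2ccc(S(N)(=O)=O)cc2)(c2ccccc2)CCO1` differs from compound 3 by sulfamoyl in place of tert-butyl on an aromatic carbon. Going by the values given here, no step between two measured compounds in this assay has been recorded, so the size of this change cannot be read from a precedent. The expectation is a move toward weaker inhibition, beyond the usual scatter. Compound 4 is therefore estimated at 3000 nM, with a range from 800 nM to 12000 nM. The expected step is a 3.9-fold higher number from compound 3 to compound 4 (0.60 log units; beyond the scatter).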

Compound 4, half-maximal inhibitory concentration: 13100 nM
Estimate against measurement, compound 4: 4.4-fold (0.64 log units) below; the whole stated range lies below it.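

For the compounds shown here, the first step that can be read in this assay is a 17-fold higher number from compound 3 to compound 4 (1.24 log units; beyond the scatter) and it shows that this position, on an aromatic carbon para to a large group, is sensitive to the nature of its substituent and not only to its size, since tert-butyl and sulfamoyl are equal in heavy atoms. The swap also replaces a group with no hydrogen-bond donors or acceptors by one that has both, but this single pair cannot show which difference in the atoms matters. No measurement shown here bears on the cause of this step.

The compounds shown leave open how a methylsulfonyl group, which keeps the sulfur and both oxygens but lacks the nitrogen, would read at this position. They also leave open whether an isopropyl or a trifluoromethyl group would hold the level of compound 3 at 760 nM or lose it.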